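Replacing 4-fluorobenzyl with 6-aminohexyl on the core

The compounds below may be only part of what the source reports. "The series", "measured", "known", "first", "only" and "open" are said of these compounds alone.

Measured so far:
compound 1 `O=C(NCc1ccc(F)cc1)c1nc(Br)c2cccnc2c1NCCCNc1c(C(=O)NCc2ccc(F)cc2)nc(Br)c2cccnc12`: > 20000 nM
compound 2 `O=C(NCc1ccc(F)cc1)c1nc(Br)c2cccnc2c1NCc1ccc(F)cc1`: > 20000 nM
compound 3 `O=CNCCCCCCNc1nc(C(=O)NCc2ccc(F)cc2)c(O)c2ncccc12`: 6000 nM

In a functional assay on HCT-116 cells (Homo sapiens) for cytotoxicity, read by MTT assay, with a stated time of 72 h (a higher number here means a weaker inhibitor, a lower number a stronger inhibitor), compound 2 gives > 20000 nM, which is a limit of the assay and not a number. Compound 1 gives > 20000 nM in this assay, again a limit and not a number. For the measured compounds named here, compound 3 gives 6000 nM in this assay, the only value among the three that is a number. Going by the values given here, compound 2 therefore stands at the limit of > 20000 nM in this assay, at which 2 of the 3 values shown sit, so no order between compound 2 and compound 1 can be read, and the only thing the numbers show is that compound 3 lies within the measured range while compound 2 does not.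

Compound 4 `NCCCCCCNc1c(C(=O)NCc2ccc(F)cc2)nc(Br)c2cccnc12` is not yet measured in this assay. It differs from compound 2 by 5-aminopentyl in place of 4-fluorophenyl on a saturated chain carbon bound to a nitrogen on an aromatic ring. Among the compounds with values here, no measured pair of compounds shares this change, so the size of the step has no precedent here; a step toward stronger inhibition, moving from the limit to a number, is expected, but not a large one.

Compound 4 is estimated at 8000 nM, with a range from 2000 nM to 30000 nM, the expected step being an at least 2.5-fold lower number from compound 2 to compound 4 (0.39 log units; beyond the scatter).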

Compound 4, half-maximal inhibitory concentration: > 10000 nM
Compound 4: a limit, no number (the forecaster's own chance of this, stated with the estimate: 35%); middle value at least 1.2-fold (0.09 log units) away from the limit.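

For the compounds shown here, compound 2 and compound 4 both sit at limits in this assay, not at numbers, so no step between them can be read. Left open is how far each compound's true value lies from its limit, and whether 6-aminohexyl in place of 4-fluorobenzyl on the shared core changes the read-out at all.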